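Cytotoxicity in the biphenyl amide series, step to compound 4

This account rests on a few compounds, and the source may have more. Where it says the series, first, only, none or still open, it means among the compounds named here.

Measured compounds in an ADME assay on Raji cells (Homo sapiens) for cytotoxicity, read by CellTiter-Glo and resazurin assay, with a stated time of 72 h; a higher number here means that more compound is needed for the effect, a lower number that less compound is needed:
- compound 1, `CC(C)N(Cc1cccc(OCCCCCC(=O)O)c1)C(=O)c1ccc(-c2ccc3c(c2)OCCO3)cc1`: > 21900 nM
- compound 2, `CC(C)N(Cc1cccc(OCCCCCC(=O)O)c1)C(=O)c1ccc(-c2cc3ccccc3n2S(=O)(=O)c2ccccc2)cc1`: > 26000 nM
- compound 3, `CCOC(=O)CCCCCOc1cccc(CN(C(=O)c2ccc(-c3cnc(OC)nc3OC)cc2)C(C)C)c1`: > 26000 nM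

All three values are limits of this assay and not numbers. Compound 1 sits at the limit of > 21900 nM in this assay, at which 1 of the 3 values shown sits. Compound 3 sits at the limit of > 26000 nM in this assay, at which 2 of the 3 values shown sit, a limit it shares with compound 2; so compound 3 stands among values that give no number at all, and no ordering of the three can be drawn from them. Going by the values given here, no pair of the measured compounds differs in one place, so no measured step is available in this assay.

Compound 4 is `CCOC(=O)CCCCCOc1cccc(CN(C(=O)c2ccc(-c3cccc(OC(F)(F)F)c3)cc2)C(C)C)c1`. It differs from compound 3 in one place: 3-(trifluoromethoxy)phenyl in place of 2,4-dimethoxypyrimidin-5-yl on an aromatic carbon.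

Among the compounds with values here, with every measured value a limit and no step to go by, the step from compound 3 to compound 4 in this assay is expected to be none beyond the scatter, with the most likely outcome again a limit. Compound 4 is estimated at 30000 nM in this assay, with a range from 8000 nM to 100000 nM, which implies a step that the limit leaves unreadable from compound 3 to compound 4.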

Compound 4, half-maximal effective concentration: > 26000 nM
Compound 4: no number, only a limit (the forecaster's own chance of this, stated with the estimate: 75%); the middle value does not contradict the limit.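

No step can be read from compound 3 to compound 4 in this assay: both values are limits of the assay and not numbers. The compounds shown leave open whether any member of the series gives a numerical half-maximal effective concentration in this assay, and whether the group on this aromatic carbon affects it.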